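This account rests on a few compounds, and the source may have more. Where it says the series, first, only, none or still open, it means among the compounds named here.

In a functional assay on L1210 cells (Mus musculus) for inhibition (a higher number here means a weaker inhibitor, a lower number a stronger inhibitor), the measured compounds are:

Compound 1 `CC(=O)OC(C)n1cnc2c(Cl)nc(I)nc21` gives 13000 nM.
Compound 2 `CC(O)n1cnc2c(N)nc(I)nc21` gives 490000 nM.
Compound 3 `Nc1nc(I)nc2c1ncn2OCCO` gives > 500000 nM, which is a limit of the assay, not a number.

Compound 3 thus sits at the limit of > 500000 nM in this assay, at which 1 of the 3 values shown sits. Going by the values given here, it is the only compound without a measured number. Among the compounds with values here, the single step between measured neighbours, an at least 1.0-fold higher number from compound 2 to compound 3 (0.00 log units; that floor lies within the scatter), lies within the scatter. Compound 4 `COc1nc(I)nc2c1ncn2OCCO` differs from compound 3 by methoxy in place of amino on an aromatic carbon. Within the data shown here, no measured step alters the amino group, so no step here bears on the size or direction of this change. Compound 4 is expected to stay near the limit, with a number no higher from compound 3 to compound 4 (the limit leaves the size open) as the expected step, giving an estimate of 500000 nM (range 150000 nM to 2000000 nM).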

Compound 4, half-maximal inhibitory concentration: > 500000 nM
Compound 4: only a limit was reported (the forecaster's own chance of this, stated with the estimate: 60%); the middle value lies on the limit itself.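

Compound 3 and compound 4 both give a limit of the assay rather than a number, so no step between them can be read: the limit of > 500000 nM in this assay, at which 2 of the 4 values shown sit.

The compounds shown leave open whether methoxy in place of amino on an aromatic carbon changes inhibition at all.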